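Replacing the dichlorobenzyl amide of compound 1 with cyclohexyl

The compounds below may be only part of what the source reports. "The series", "measured", "known", "first", "only" and "open" are said of these compounds alone.

Compound 1 `N[C@H]1CC[C@H](Nc2c(C(=O)NCc3ccc(Cl)cc3Cl)nc(Br)c3cccnc23)CC1` gives the lowest of the two numbers recorded in a functional assay on HEY cells (Homo sapiens) for cytotoxicity, read by MTT assay, with a stated time of 72 h (on this read-out lower numbers stand for stronger inhibition and higher numbers for weaker inhibition), at 5000 nM. Compound 3 `N[C@H]1CC[C@H](Nc2c(C(=O)NCc3cccc(C(F)(F)F)c3)nc(Br)c3cccnc23)CC1` sits nearest, at 12000 nM, and the step of a 2.4-fold higher number from compound 1 to compound 3 (0.38 log units; beyond the scatter) is modest but beyond the scatter. Compound 2 `COC(=O)c1nc(Br)c2cccnc2c1N[C@H]1CC[C@H](N)CC1` gives only a limit of the assay in this assay, > 20000 nM; as the evidence notes, (the limit of > 20000 nM in this assay, at which 1 of the 3 values shown sits).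

Compound 4 `N[C@H]1CC[C@H](Nc2c(C(=O)NC3CCCCC3)nc(Br)c3cccnc23)CC1` has not yet been measured in this assay. It differs from compound 1 by cyclohexyl in place of 2,4-dichlorobenzyl on an amide-type nitrogen. Among the compounds with values here, two measured steps bear on this change. The step of a 2.4-fold higher number from compound 1 to compound 3 (0.38 log units; beyond the scatter) shows that exchanging one aromatic group on that amide for another already costs potency, and the step of an at least 4.0-fold higher number from compound 1 to compound 2 (0.60 log units; beyond the scatter) shows that removing the benzylamide altogether costs at least as much. Since cyclohexyl removes the aromatic ring while keeping the amide, a weakening step is expected, estimated as a 2.4-fold higher number from compound 1 to compound 4 (0.38 log units; beyond the scatter). Compound 4 is therefore expected to give about 12000 nM in this assay, within a range of 5000 nM to 30000 nM.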

Compound 4, half-maximal inhibitory concentration: 5200 nM
Beside the measured number, compound 4's estimate is 2.3-fold (0.36 log units) above it; the range from low to high includes it.
By their numbers in this assay, from the lowest: compounds 1 and 4 (each within the scatter of the next); then compound 3. At a limit, above all of these: compound 2.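

In this assay, the step of a 1.0-fold higher number from compound 1 to compound 4 (0.02 log units; within the scatter) shows that an aromatic ring on this amide-type nitrogen is not required to keep the value of compound 1, since a non-aromatic cyclohexyl serves equally well. The step of a 2.3-fold lower number from compound 3 to compound 4 (0.36 log units; beyond the scatter) then shows that the loss seen with compound 3 belongs to the 3-(trifluoromethyl)benzyl group itself and not to any departure from 2,4-dichlorobenzyl. The step of an at least 3.8-fold lower number from compound 2 to compound 4 (0.58 log units; beyond the scatter) extends the earlier reading to a non-aromatic amide, although it is counted from compound 2, which stands only at a limit: the limit of > 20000 nM in this assay, at which 1 of the 4 values shown sits.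

On these data alone, whether a much shorter group on this nitrogen, such as methyl, would hold the value remains open. So does whether a carboxylic acid in place of the amide would behave like the methoxy of compound 2.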